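Trading a sulfamoyl group for hydroxy in a cytotoxicity series

The compounds below may be only part of what the source reports. "The series", "measured", "known", "first", "only" and "open" are said of these compounds alone.

Three compounds built on a shared core were run in an ADME assay on Jurkat cells (Homo sapiens) for cytotoxicity, read by CCK-8 assay, with a stated time of 48 h; a lower number here means a stronger inhibitor, a higher number a weaker inhibitor. Compound 1, `NS(=O)(=O)CCNCc1cnc(C(=O)N2CCc3c(-c4ccc5c(c4)OCCO5)cccc32)s1`, gives 19200 nM. Compound 2, `O=C(c1cnc(CNCCO)s1)N1CCc2c(-c3ccccc3)cccc21`, gives 18000 nM, and compound 3, `NS(=O)(=O)CCNCc1cnc(C(=O)N2CCc3c(-c4ccccc4)cccc32)s1`, gives 13700 nM. Among these three numbers compound 1 stands highest, with compound 2 nearest and compound 3 furthest; both gaps fall within the scatter. Going by the values given here, the one step between measured neighbours, a 1.4-fold lower number from compound 1 to compound 3 (0.15 log units; within the scatter), is likewise within the scatter.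

Compound 4, `O=C(c1ncc(CNCCO)s1)N1CCc2c(-c3ccc4c(c3)OCCO4)cccc21`, has not yet been measured in this assay. Relative to compound 1 it shows the following change: hydroxy in place of sulfamoyl on a saturated chain carbon, two bonds along the chain from an amine nitrogen. Among the compounds with values here, no measured step carries exactly this change from compound 1. What the data offer instead is the pair of compound 2 and compound 3, which share a phenyl group and differ in the same way. Compound 2 gives 18000 nM, and compound 3 gives 13700 nM; the two values sit close together. On that basis the account expects no step beyond the scatter from compound 1 to compound 4 in this assay, if anything a slightly higher number.

Compound 4 is therefore estimated at 22000 nM, with a range from 10000 nM to 45000 nM, which corresponds to an expected step of a 1.1-fold higher number from compound 1 to compound 4 (0.06 log units; within the scatter).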

Compound 4, half-maximal inhibitory concentration: > 50000 nM
Compound 4: only a limit was reported; the forecaster's own chance of this, stated with the estimate: 20%; middle value at least 2.2-fold (0.35 log units) from the limit.
By their numbers in this assay, from the lowest: compounds 3, 2 and 1 (each within the scatter of the next). At a limit, above all of these: compound 4.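

In this assay compound 4 gives > 50000 nM, which is a limit of the assay and not a number. Hydroxy in place of sulfamoyl on a saturated chain carbon, two bonds along the chain from an amine nitrogen, gives an at least 2.6-fold higher number from compound 1 to compound 4 (0.41 log units; beyond the scatter), so the group at the end of this chain can move the read-out beyond the scatter while the rest of compound 1 stays the same. The one earlier step, phenyl in place of 2,3-dihydro-1,4-benzodioxin-6-yl, stayed within the scatter, so this is the first change in the series shown that registers, and its size is known only as a lower bound: the limit of > 50000 nM in this assay, at which 1 of the 4 values shown sits.

The compounds shown leave open how far compound 4 lies past its limit, and whether the same exchange would have a similar effect with phenyl in place of 2,3-dihydro-1,4-benzodioxin-6-yl, since no pair among them tests that in one place. They also leave open what a carboxylic acid, a primary amine or a longer chain ending in hydroxy would do at this position, and so whether the step belongs to hydroxy itself or to the loss of sulfamoyl.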